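A few compounds are considered here, and "the series" means these few. Any claim that something is new, unique, unknown or untested is made for them only; others in the source may bear on it.

Measured compounds
- compound 1, `COc1ccc(-c2ccnc(C(=O)Nc3ccc(Oc4ccnc5[nH]ccc45)cc3)c2)cc1`: 8210 nM
- compound 2, `CCc1ccc(-c2ccnc(C(=O)Nc3ccc(Oc4ccnc5[nH]ccc45)c(F)c3)c2)cc1`: 7470 nM

Both numbers come from a functional assay on MCF7 cells (Homo sapiens) for cytotoxicity, read by MTT assay, with a stated time of 72 h; on this read-out higher numbers stand for weaker inhibition and lower numbers for stronger inhibition. In this assay compound 2 gives 7470 nM and compound 1 gives 8210 nM; compound 2 holds the lower of the two numbers, but its nearest neighbour, compound 1, sits within the scatter of it, so no order between the two can be read from these figures. Compound 3, `COc1ccc(-c2ccnc(C(=O)Nc3ccc(Oc4ccnc5[nH]ccc45)c(F)c3)c2)cc1`, has not been measured in this assay. It departs from compound 2 in one place: methoxy in place of ethyl on an aromatic carbon. Among the compounds with values here, no step between measured compounds maps this change on its own. Within the data shown here, what can be said is that compound 1 carries the same methoxyphenyl arm as compound 3, and that compound 1 and compound 2 give numbers within the scatter of each other, so the whole series so far sits in a narrow band. The expectation for the move is therefore a 1.1-fold higher number from compound 2 to compound 3 (0.03 log units; within the scatter), no shift beyond the scatter in either direction. Compound 3 is estimated at 8000 nM, with a range from 3500 nM to 18000 nM.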

Compound 3, half-maximal inhibitory concentration: 9110 nM
Beside the measured number, compound 3's estimate is 1.1-fold (0.06 log units) below it; the range from low to high includes it.
By their numbers in this assay, from the lowest: compounds 2, 1 and 3 (each within the scatter of the next).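

In this assay, within the data shown here, 4-ethylphenyl to 4-methoxyphenyl with the fluoro group held constant gives a 1.2-fold higher number from compound 2 to compound 3 (0.09 log units; within the scatter), the first reading of this change on its own: trading ethyl for methoxy on this aromatic carbon, which also brings in a hydrogen-bond acceptor, leaves the number within the scatter. With the 4-methoxyphenyl arm held constant, fluoro in place of hydrogen gives a 1.1-fold higher number from compound 1 to compound 3 (0.05 log units; within the scatter), so this change can now be read separately too, whereas compound 1 and compound 2 differ in both places and could only show that the two changes together left the numbers within the scatter. No measurement at hand accounts for these flat steps.

Still open, on these data alone, is whether any group at this aromatic carbon moves the number beyond the scatter, for instance an amine, a carboxylic acid or a chain longer than ethyl, such as butyl. Also open, as far as these compounds go, is how fluoro in place of hydrogen reads with the 4-ethylphenyl arm, and so whether the flat fluoro step holds beyond the 4-methoxyphenyl arm.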